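Three Measured Compounds and One Expected Value

The source may hold more compounds than are shown below. What is called first, only, known or untested is meant among the compounds shown, and "the series" means these compounds.

Compound 1 `CCOC(=O)C1=C(C)NC(C)=C(C(=O)OCC)C1c1ccc(OCC(=O)NCc2ccccc2)cc1` in a functional assay on the whole organism (strain Wistar) for inhibition, with Rattus norvegicus as the target, read by paw edema, with stated times of 30 min and 0.5 h, at a dose of 20 mg/kg; a higher number here means more inhibition at the dose given (going by the name of the read-out), a lower number less inhibition: compound 1 gives 8.33%.
Compound 2 `CCOC(=O)C1=C(C)NC(C)=C(C(=O)OCC)C1c1ccc(OCC(=O)Nc2c(C)cccc2C)cc1`: compound 2 gives 15.9%.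
Compound 3 `CCOC(=O)C1=C(C)NC(C)=C(C(=O)OCC)C1c1ccc(OCC(=O)NNC(=O)c2ccsc2Cl)cc1`: compound 3 gives 12.9%.

Compound 3 stands second highest of the three numbers, with a number 3 percentage points lower from compound 2 to compound 3 (within the scatter) and a number 4.6 percentage points higher from compound 1 to compound 3 (within the scatter), so all three sit within the scatter of one another. Compound 4 `CCOC(=O)C1=C(C)NC(C)=C(C(=O)OCC)C1c1ccc(OCC(=O)n2nc(C)cc2C)cc1` differs from compound 3 in that (a group of 7 heavy atoms (5 carbon, 2 nitrogen; one five-membered aromatic ring with 2 hetero atoms) in place of a group of 10 heavy atoms (5 carbon, 2 nitrogen, 1 oxygen, 1 sulfur, 1 chlorine; one five-membered aromatic ring with 1 hetero atom), on a carbonyl carbon). The measured steps of a number 7.6 percentage points higher from compound 1 to compound 2 (within the scatter), a number 4.6 percentage points higher from compound 1 to compound 3 (within the scatter) and a number 3 percentage points lower from compound 2 to compound 3 (within the scatter) all swapped groups on an amide-type nitrogen, not on the carbonyl carbon, so none bears directly on this change, and each stayed within the scatter. Compound 4 is therefore expected to show no step beyond the scatter, a number 0.9 percentage points lower from compound 3 to compound 4 (within the scatter). The estimate for compound 4 is 12%, between 2% and 25%.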

Compound 4, a percentage reported as inhibition, in the whole organism at one dose (the size of the read-out at that dose, not a potency): 13.7%
Compound 4: middle estimate off by 1.7 percentage points, on the low side; low and high end bracket the measured number.
By their numbers in this assay, from the lowest: compounds 1, 3, 4 and 2 (each within the scatter of the next).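

The earlier steps shown here all lay on an amide-type nitrogen, whereas here the whole group on the carbonyl carbon changes, with 3,5-dimethyl-1H-pyrazol-1-yl, which has 0 hydrogen-bond donors, entering in this assay. Even so, the number shifts only by a number 0.8 percentage points higher from compound 3 to compound 4 (within the scatter) and by a number 2.2 percentage points lower from compound 2 to compound 4 (within the scatter) and by a number 5.4 percentage points higher from compound 1 to compound 4 (within the scatter) and so, at this position too, no step leaves the scatter. No measurement offered here explains this result.

As far as these compounds go, whether any group on this carbonyl carbon can move the number beyond the scatter stays open. A free carboxylic acid or a morpholine amide there would test this.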